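This account rests on a few compounds, and the source may have more. Where it says the series, first, only, none or still open, it means among the compounds named here.

Measured so far:
compound 1, `CCC1(Cc2ccccc2)OS(=O)(=O)C=C1OC`: > 400000 nM
compound 2, `CCC1(Cc2ccccc2)OS(=O)(=O)C=C1NCc1ccccc1`: >= 80000 nM

In an ADME assay on HEL cells (Homo sapiens) for cytotoxicity, with a stated time of 3 days (a lower number here means that less compound is tolerated, a higher number that more compound is tolerated), compound 1 gives > 400000 nM, which is a limit of the assay rather than a number. Compound 2 gives >= 80000 nM in this assay, also a limit. Within the data shown here, because both values sit at limits (the limit of > 400000 nM in this assay, at which 1 of the 2 values shown sits, and (the limit of >= 80000 nM in this assay, at which 1 of the 2 values shown sits)), the step that the two limits leave unreadable from compound 1 to compound 2 cannot be read, so compound 1 stands only at a limit, with no measured step of known size to lean on.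

Compound 3, `CCC1(Cc2ccccc2)OS(=O)(=O)C=C1OCc1ccc([N+](=O)[O-])cc1`, differs from compound 1 by 4-nitrophenyl in place of hydrogen on a saturated chain carbon bound to an oxygen on an unsaturated carbon. Among the measured compounds shown here, no measured step bears on this change, so the expectation rests on compound 1 alone, whose value is a limit. The step of an at least 2.0-fold lower number from compound 1 to compound 3 (0.30 log units; that floor lies within the scatter) is therefore expected to be small, with no clear direction, and a limit is again likely. The estimate for compound 3 in this assay is 200000 nM, within a range from 40000 nM to 400000 nM.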

Compound 3, minimum cytotoxic concentration: >= 80000 nM
Compound 3: only a limit was reported; the forecaster's own chance of this, stated with the estimate: 60%; the middle value does not contradict the limit.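

Compound 1 and compound 3 both stand at limits in this assay, not at numbers, so the step between them cannot be read. The compounds shown leave open whether 4-nitrophenyl in place of hydrogen changes the concentration these cells tolerate at all.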